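Triazole N-aryl variation in the bicyclic lactam series

The source may hold more compounds than are shown below. What is called first, only, known or untested is meant among the compounds shown, and "the series" means these compounds.

Compound 3 `CC1(C)[C@H]2CC[C@]1(C)N(Cc1cn(-c3ccc(Br)cc3)nn1)C(=O)C2` carries a 4-bromophenyl on the triazole nitrogen. In a functional assay on SGC-7901 cells (Homo sapiens) for inhibition, read by MTT assay, with a stated time of 24 h (on this read-out lower numbers stand for stronger inhibition and higher numbers for weaker inhibition), compound 3 gives 450 nM. It stands second highest of the three numbers measured: compound 2 `CC1(C)[C@H]2CC[C@]1(C)N(Cc1cn(-c3ccc(F)cc3)nn1)C(=O)C2`, which gives 500 nM, sits within the scatter of it, and compound 1 `CC1(C)[C@H]2CC[C@]1(C)N(Cc1cn(-c3ccccc3)nn1)C(=O)C2`, the unsubstituted phenyl, which gives 240 nM, is also within the scatter, so no ordering among the three is secure.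

Compound 4 `Cc1cccc(-n2cc(CN3C(=O)C[C@@H]4CC[C@@]3(C)C4(C)C)nn2)c1` differs from compound 3 by 3-methylphenyl in place of 4-bromophenyl on an aromatic nitrogen. The measured steps that bear on it are all changes on the phenyl ring: a 2.1-fold higher number from compound 1 to compound 2 (0.32 log units; beyond the scatter), a 1.9-fold higher number from compound 1 to compound 3 (0.27 log units; within the scatter) and a 1.1-fold lower number from compound 2 to compound 3 (0.05 log units; within the scatter). None of them moves this assay by much, so a substituent swap on this ring is expected to leave the number close to where it is. Among the measured compounds shown here, no measured compound carries a 3-methylphenyl, so the step of a 1.2-fold lower number from compound 3 to compound 4 (0.07 log units; within the scatter) is an expectation drawn only from the small swings seen so far. Compound 4 is estimated at 380 nM, with a range of 150 nM to 950 nM.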

Compound 4, half-maximal inhibitory concentration: 410 nM
The estimate for compound 4 lay 1.1-fold (0.03 log units) below the measured number; low and high end bracket the measured number.
By their numbers in this assay, from the lowest: compounds 1, 4, 3 and 2 (each within the scatter of the next, the first and the last beyond it).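

In this assay, 3-methylphenyl in place of 4-bromophenyl on the aromatic nitrogen gives a 1.1-fold lower number from compound 3 to compound 4 (0.04 log units; within the scatter), and in place of 4-fluorophenyl it gives a 1.2-fold lower number from compound 2 to compound 4 (0.09 log units; within the scatter), so a ring bearing methyl cannot be told apart from either halogen-bearing ring. Among the compounds shown here, the same substituent against the unsubstituted phenyl gives a 1.7-fold higher number from compound 1 to compound 4 (0.23 log units; within the scatter), which leaves the step from compound 1 to compound 2 as the only one on this ring beyond the scatter. Both the substituent and its place on the ring differ between compound 3 and compound 4, and still no separation appears. Nothing available explains these numbers.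

Open, as far as these compounds go, is whether an amine or a carboxylic acid on this phenyl ring would separate from these compounds. Also open, from the compounds shown here alone, is what a longer chain in place of the aryl group on this nitrogen would do.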